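Replacing Iodo with a Benzyloxyethoxy Chain: Compound 4 Expected

This account rests on a few compounds, and the source may have more. Where it says the series, first, only, none or still open, it means among the compounds named here.

Measured so far:
Compound 1 `COc1ccccc1Sc1c[nH]c2ccc(Cl)cc12` in a functional assay on MCF7 cells (Homo sapiens) for inhibition, with a stated time of 48 h (on this read-out higher numbers stand for weaker inhibition and lower numbers for stronger inhibition), gives > 2500 nM, which is a limit of the assay and not a number.
Compound 2 `COc1cc(Sc2c[nH]c3ccc(I)cc23)cc(OC)c1OC` in this assay gives 68 nM.
Compound 3 `COc1cc(Sc2c[nH]c3ccc(O)cc23)cc(OC)c1OC` in this assay gives 190 nM.

Compound 2 holds the lowest of the two numbers; its nearest neighbour is compound 3, reached by a 2.8-fold higher number from compound 2 to compound 3 (0.45 log units; beyond the scatter). Compound 1 sits at the limit of > 2500 nM in this assay, at which 1 of the 3 values shown sits.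

Compound 4 `COc1cc(Sc2c[nH]c3ccc(OCCOCc4ccccc4)cc23)cc(OC)c1OC` differs from compound 2 by 2-(benzyloxy)ethoxy in place of iodo on an aromatic carbon. Among the compounds with values here, the only measured step that bears on this change is the one from compound 2 to compound 3, which also removes the iodo and puts an oxygen-linked group in its place; that step was modest, beyond the scatter, and toward weaker inhibition. Within the data shown here, the 2-(benzyloxy)ethoxy group is far larger than hydroxy, and no measured pair covers a group of that size, so the expectation is uncertain. A modest weakening of similar size is expected, a 2.9-fold higher number from compound 2 to compound 4 (0.47 log units; beyond the scatter), with a wide range either way. Compound 4 is therefore estimated at 200 nM, between 50 nM and 1000 nM.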

Compound 4, half-maximal inhibitory concentration: 260 nM
Compound 4: middle estimate off by 1.3-fold (0.11 log units), on the low side; the range from low to high includes it.
By their numbers in this assay, from the lowest: compound 2; then compounds 3 and 4 (each within the scatter of the next). At a limit, above all of these: compound 1.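

Putting 2-(benzyloxy)ethoxy, with its 11 heavy atoms and a six-membered aromatic ring, in place of iodo gives a 3.8-fold higher number from compound 2 to compound 4 (0.58 log units; beyond the scatter) as a modest step toward weaker inhibition. The new finding is that building onto the oxygen of compound 3 gives a 1.4-fold higher number from compound 3 to compound 4 (0.14 log units; within the scatter) so that adding 2-(benzyloxy)ethyl to the hydroxy group leaves no change that can be told from the scatter, and this position on the shared core therefore accepts a far larger group without a further loss. None of the information at hand explains why these steps have the sizes they do.

Going by these compounds, it remains open whether the chain's aromatic ring matters, as a plain ethoxy group would show. On these data alone, it is also open how a chain ending in an amine or a carboxylic acid would behave at this position.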